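A few compounds are considered here, and "the series" means these few. Any claim that something is new, unique, unknown or untested is made for them only; others in the source may bear on it.

Compound 1 `C/C(=C\CC/C(C)=C/CC[C@@H]1[C@@]2(C)CCC(=O)C(C)(C)[C@H]2CC[C@@]1(C)O)CC/C=C(\C)C(=O)OCc1cn(-c2ccccc2C(F)(F)F)nn1`: > 150000 nM
Compound 2 `COc1ccc(-n2cc(COC(=O)/C(C)=C/CC/C(C)=C/CC/C(C)=C/CC[C@@H]3[C@@]4(C)CCC(=O)C(C)(C)[C@H]4CC[C@@]3(C)O)nn2)cc1`: 135000 nM

Both compounds were tested in a functional assay on DU-145 cells (Homo sapiens) for antiproliferative activity, read by MTT assay, with a stated time of 48 h; on this read-out higher numbers stand for weaker inhibition and lower numbers for stronger inhibition. Compound 1 reads > 150000 nM, which is a limit of the assay and not a number. Within the data shown here, compound 2 gives 135000 nM, the only true number in this small set, so its standing rests on a single comparison.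

Compound 3 `C/C(=C\CC/C(C)=C/CC[C@@H]1[C@@]2(C)CCC(=O)C(C)(C)[C@H]2CC[C@@]1(C)O)CC/C=C(\C)C(=O)OCc1cn(-c2ccc(Br)cc2)nn1` is compound 2 with one change, bromo in place of methoxy on an aromatic carbon. Among the measured compounds shown here, the one measured step, an at least 1.1-fold lower number from compound 1 to compound 2 (0.04 log units; that floor lies within the scatter), also changed a group on that aryl ring and stayed within the scatter. Resting on that step, no change beyond the scatter is expected in this assay. Compound 3 could also end at the limit of > 150000 nM in this assay, at which 1 of the 2 values shown sits, which would be a limit rather than a number. The expected step is a 1.0-fold lower number from compound 2 to compound 3 (0.02 log units; within the scatter). For compound 3 the estimated value is 130000 nM, with an expected range from 70000 nM to 220000 nM.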

Compound 3, half-maximal inhibitory concentration: > 150000 nM
Compound 3 gave a limit, no number (the forecaster's own chance of this, stated with the estimate: 40%); middle value at least 1.1-fold (0.06 log units) away from the limit.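

Going by these compounds, replacing methoxy with bromo on this aromatic carbon gives an at least 1.1-fold higher number from compound 2 to compound 3 (0.04 log units; that floor lies within the scatter), so the change can only be read as a floor, and its true size stays unknown. In this assay compound 3 ends at a limit and not a number, as compound 1 does: the limit of > 150000 nM in this assay, at which 2 of the 3 values shown sit. The step between these two compounds cannot be read, so changing this aryl group has still produced no step shown to lie beyond the scatter, and compound 2 remains the only one with a true number.

On these data alone, what stays open is whether any group on this ring can bring the number clearly lower, for example an amine or a carboxylic acid in the place of methoxy or bromo. As far as these compounds go, it is also open how far above the limit compound 1 and compound 3 really lie.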